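The compounds below may be only part of what the source reports. "The series", "measured", "known", "first", "only" and "open" are said of these compounds alone.

Measured compounds:
compound 1 `Nc1sccc1C(=O)c1ccc(Cl)cc1` — 40%
compound 2 `COc1ccc(-c2cc(C(=O)c3ccccc3)c(N)s2)cc1` — 14%
compound 3 `Nc1sc(-c2ccncc2)cc1C(=O)c1ccccc1` — 17%

In an assay on CHO cells for positive allosteric modulation of adenosine receptor A1 (Homo sapiens), read by ERK phosphorylation, tested at 10 uM (on this read-out higher numbers stand for a weaker effect at the one concentration tested and lower numbers for a stronger effect), compound 1 gives 40%, the highest of the three numbers and hence the weakest effect seen so far. Compound 3 gives 17%, a number that sits beyond the scatter below compound 1, and compound 2 gives 14%, the lowest of the set and also beyond the scatter from compound 1. Within the data shown here, both compounds 2 and 3 carry an additional aromatic ring on the shared core, whereas compound 1 does not; no single-change step connects them to compound 1, so their values stand only as a hint.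

Compound 4 `Nc1sc(-c2ccccc2)cc1C(=O)c1ccc(Cl)cc1` has not yet been measured. It differs from compound 1 in one place: phenyl in place of hydrogen on an aromatic carbon. Given that compounds 2 and 3 with an added aromatic ring show lower numbers, the expected step of a number 22 percentage points lower from compound 1 to compound 4 (beyond the scatter) in this assay is toward a stronger effect, beyond the scatter. The estimate for compound 4 is therefore 18%, within a range from 8% to 32%.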

Compound 4, a percentage reported as activity, at one concentration (the size of the read-out at that concentration, not a potency): 16%
For compound 4 the middle estimate is 2 percentage points above the measured one, within the range that was stated.
By their numbers in this assay, from the lowest: compounds 2, 4 and 3 (each within the scatter of the next); then compound 1.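

In this assay, phenyl in place of hydrogen on an aromatic carbon, next to the ring sulfur, gives a number 24 percentage points lower from compound 1 to compound 4 (beyond the scatter). Among these compounds, this is the first reading of this position with the rest of the molecule held the same, so the earlier hint now rests on a single change that moves the number beyond the scatter toward a stronger effect. No measurement shown here explains why the added ring has this effect.

Going by these compounds, the result comes from one pair, so it remains open whether an aromatic ring is needed at this position or whether a methyl group, a longer alkyl chain or a saturated cyclohexyl ring would give a similar step. On these data alone, it is also open whether the step would be the same without the chlorine on the other ring.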